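A few compounds are considered here, and "the series" means these few. Any claim that something is new, unique, unknown or untested is made for them only; others in the source may bear on it.

Working notes on the coumarin-type amide series.

Compound 1 `O=C(NC1CCCC1)c1cc2ccccc2oc1=O` gives 20% in an assay on HeLa cells for displacement of a labelled ligand from adenosine receptor A3 (Homo sapiens), read by scintillation counting, with a stated time of 180 min, tested at 10 uM; a lower number here means less inhibition, a higher number more inhibition at the concentration tested (going by the name of the read-out). Compound 2 `O=C(NCCCO)c1cc2ccccc2oc1=O` carries the change 3-hydroxypropyl in place of cyclopentyl on an amide-type nitrogen and gives 6% in this assay, the step being a number 14 percentage points lower from compound 1 to compound 2 (beyond the scatter). Compound 3 `N=c1oc2ccc(Br)cc2cc1C(=O)NC1CCCC1` has a core that differs from that of compound 1 in more than one place; the difference between the two cores is not broken down here. Compound 3 gives 0% in this assay; set against compound 2 the two numbers lie within the scatter of one another, set against compound 1 the gap is beyond it.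

Compound 4 `N=c1oc2ccc(Br)cc2cc1C(=O)NCCCO` is the not yet measured partner of compound 3 and differs from it by 3-hydroxypropyl in place of cyclopentyl on an amide-type nitrogen, the same change at the same place as from compound 1 to compound 2. That earlier step lowered the read-out; compound 3 itself gives 0% in this assay, and a fall of the same size below that number is not expected. The expected step from compound 3 to compound 4 is therefore a number 1 percentage points higher from compound 3 to compound 4 (within the scatter), within the scatter. Compound 4 is expected to give 1% in this assay, between -8% and 10%.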

Compound 4, a percentage reported as inhibition, at one concentration (the size of the read-out at that concentration, not a potency): 17%
Compound 4: middle estimate off by 16 percentage points, on the low side; the whole stated range lies below it.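

In this assay, 3-hydroxypropyl in place of cyclopentyl on an amide-type nitrogen gives a number 17 percentage points higher from compound 3 to compound 4 (beyond the scatter), so the change does not carry over from the core of compound 1 to the core of compound 3 with the same direction or size: the same change on two cores in this assay, a number 14 percentage points lower (beyond the scatter) from compound 1 to compound 2 and a number 17 percentage points higher (beyond the scatter) from compound 3 to compound 4, 31 percentage points apart, beyond the scatter of two such steps. For the compounds shown here, for these two pairs, a step measured on one core therefore gives no guide to the step on the other. This does not show which of the differences between the two cores goes with the reversal, and two pairs support no rule for the wider series.

The compounds shown leave open whether a core carrying only one of those differences would follow the step to compound 2 or the step to compound 4. Also open, going by these compounds, is how a longer chain, an amine or a carboxylic acid in place of 3-hydroxypropyl on the amide-type nitrogen would read out on either core.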